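A few compounds are considered here, and "the series" means these few. Any claim that something is new, unique, unknown or untested is made for them only; others in the source may bear on it.

Compound 1 `C[C@@H]1N[C@H](C(=O)N2CCC[C@H]2C#N)C[C@@H]1C(=O)N1CCC1`: 88%
Compound 2 `N#C[C@@H]1CCCN1C(=O)[C@@H]1C[C@H](C(=O)N2CCC2)CN1`: 46%

In an assay on the whole organism (plasma, strain Sprague-Dawley) for inhibition of Dipeptidyl peptidase 4 (Rattus norvegicus), with a stated time of 10 h, at a dose of 1 mg/kg by the oral route (a lower number here means less inhibition, a higher number more inhibition at the dose given (going by the name of the read-out)), compound 1 gives 88%, the highest of the two numbers shown. Compound 2 gives 46%. For the measured compounds named here, the one measured step, a number 42 percentage points lower from compound 1 to compound 2 (beyond the scatter), is hydrogen in place of methyl on a saturated ring carbon, a different place from the change considered here. Compound 3 `C[C@@H]1N[C@H](C(=O)N2CCC[C@H]2C#N)C[C@@H]1C(=O)N(C)C` differs from compound 1 in one place: dimethylamino in place of azetidin-1-yl on a carbonyl carbon. Going by the values given here, no measured step bears directly on this change, so only a small step, if any beyond the scatter, is expected: a number 8 percentage points lower from compound 1 to compound 3 (within the scatter). Compound 3 is therefore estimated at 80%, with a range from 60% to 92%.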

Compound 3, a percentage reported as inhibition, in the whole organism at one dose (the size of the read-out at that dose, not a potency): 84%
Compound 3: the middle estimate sits 4 percentage points below what was measured, within the range that was stated.
By their numbers in this assay, from the lowest: compound 2; then compounds 3 and 1 (each within the scatter of the next).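

The step on this carbonyl carbon, dimethylamino in place of azetidin-1-yl, is a number 4 percentage points lower from compound 1 to compound 3 (within the scatter) in this assay. The earlier compounds shown here differed only at the saturated ring carbon, whereas this pair shows that, at this dose and time, the four-membered ring can give way to an open group with no step beyond the scatter. Nothing at hand explains this result. As far as these compounds go, it remains open how a larger group such as piperidin-1-yl, or methylamino, would read on this carbonyl carbon. A single-dose reading also leaves potency open.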